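Cyano for Fluoro on the Aryl Tetrazole

The source may hold more compounds than are shown below. What is called first, only, known or untested is meant among the compounds shown, and "the series" means these compounds.

Of the compounds shown here, two have so far been measured in an assay on HEK293 cells for activation of Kir3.1/Kir3.2 (Homo sapiens), read by thallium flux; a higher number here means that more compound is needed for the effect, a lower number that less compound is needed. Compound 1, `CC1CC1c1cc(NC(=O)Cn2nnc(-c3ccccc3)n2)n(C2CCCCC2)n1`, gives 843 nM, whereas compound 2, `Cc1cc(NC(=O)Cn2nnc(-c3cccc(F)c3)n2)n(C2CCCCC2)n1`, gives 81 nM, the lowest of the two numbers and a gap beyond the scatter. Compound 3, `Cc1cc(NC(=O)Cn2nnc(-c3cccc(C#N)c3)n2)n(C2CCCCC2)n1`, is not yet measured; it differs from compound 2 by cyano in place of fluoro on an aromatic carbon. For the measured compounds named here, no measured pair isolates this change, so compound 3 is expected to differ little, the step being estimated as a 1.5-fold higher number from compound 2 to compound 3 (0.17 log units; within the scatter), within the scatter. For compound 3 the estimate in this assay is 120 nM, with a range from 40 nM to 400 nM.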

Compound 3, half-maximal effective concentration: 183 nM
For compound 3 the middle estimate is 1.5-fold (0.18 log units) below the measured one, within the range that was stated.
By their numbers in this assay, from the lowest: compound 2; then compound 3; then compound 1.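

In this assay, for the compounds shown here, the change from 3-fluorophenyl to 3-cyanophenyl gives the first reading at this position with all else held constant, a modest step of a 2.3-fold higher number from compound 2 to compound 3 (0.35 log units; beyond the scatter) in the direction of more compound being needed. The position therefore accepts cyano, with its hydrogen-bond acceptor, in place of fluoro, though at a small cost in this read-out. No information at hand accounts for this step.

Going by these compounds, how a chloro or methoxy group, or an amine, on the same carbon would read remains open. So does whether the same change would give a similar step on a different core.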